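Adding a Second Chloro to the Purine Core of Compound 1

A few compounds are considered here, and "the series" means these few. Any claim that something is new, unique, unknown or untested is made for them only; others in the source may bear on it.

Measured compounds:
Compound 1 `ClCc1cccc(Cn2cnc3ncnc(Cl)c32)c1`: 47900 nM
Compound 2 `ClCc1ccc(Cn2cnc3nc(Cl)nc(Cl)c32)cc1`: "not determined" (no result reported)

In a functional assay on RXF 393 cells (Homo sapiens) for cytotoxicity, read by sulforhodamine B assay, with a stated time of 48 h (on this read-out higher numbers stand for lower toxicity in this test and lower numbers for higher toxicity in this test), compound 1 gives 47900 nM. Among the measured compounds shown here, this is the only number in the set, so compound 1 stands alone; compound 2 `ClCc1ccc(Cn2cnc3nc(Cl)nc(Cl)c32)cc1` carries "not determined" (no result reported) in this assay, and nothing can be said about how the two compare.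

Compound 3 `ClCc1cccc(Cn2cnc3nc(Cl)nc(Cl)c32)c1` is not yet measured. It differs from compound 1 by chloro in place of hydrogen on an aromatic carbon. For the measured compounds named here, no pair of measured compounds shows the effect of this change, so the size of the step from compound 1 to compound 3 in this assay is unknown. Going by the values given here, the expected step is small: either none beyond the usual scatter or a modest shift toward higher toxicity, because the only anchor is compound 1 at 47900 nM. Compound 3 is therefore estimated at 35000 nM, within 10000 nM to 100000 nM, which means an expected step of a 1.4-fold lower number from compound 1 to compound 3 (0.14 log units; within the scatter).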

Compound 3, concentration lethal to 50% of the cells: 5120 nM
Estimate against measurement, compound 3: 6.8-fold (0.83 log units) above; the measured number lies below the stated range.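

In this assay, chloro in place of hydrogen on an aromatic carbon between two ring nitrogen atoms brings a 9.4-fold lower number from compound 1 to compound 3 (0.97 log units; beyond the scatter) and so moves the read-out toward higher toxicity in this test. Among the compounds shown here, this is the first sign that the position is not silent, since one added heavy atom on the core of compound 1 is enough to take the number beyond the scatter. Nothing available bears on why the number falls.

As far as these compounds go, whether this shift belongs to chloro itself or would also follow other groups on the same aromatic carbon stays open, and an amine or a methoxy group there would test this. Compound 2 has no number, so any step involving it cannot be read.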